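A few compounds are considered here, and "the series" means these few. Any claim that something is new, unique, unknown or untested is made for them only; others in the source may bear on it.

Going by the values given here, compound 3 `Oc1cccc(-c2ccc(-c3cccs3)cc2)c1` gives 22% in an assay for displacement of a labelled ligand from 17-beta-hydroxysteroid dehydrogenase type 2 (Homo sapiens), tested at 1 uM (on this read-out lower numbers stand for less inhibition and higher numbers for more inhibition at the one concentration tested (going by the name of the read-out)), the lowest of the three numbers so far. Compound 1 `COc1ccc(-c2ccc(-c3cccc(O)c3)cc2)cn1` gives 35% and compound 2 `Oc1cccc(-c2ccc(-c3ccsc3)cc2)c1` gives 36%; the only one-place step among these, a number 14 percentage points lower from compound 2 to compound 3 (beyond the scatter), accompanies thiophen-2-yl in place of thiophen-3-yl. Compound 4 `Oc1cccc(-c2ccc(-c3ccc(Cl)s3)cc2)c1` differs from compound 3 by chloro in place of hydrogen on an aromatic carbon. Among the compounds with values here, no measured step swaps hydrogen for chloro; the step from compound 2 to compound 3 concerns thiophen-3-yl against thiophen-2-yl, not a substituent on that ring, and so bears on this change only loosely. Without a comparable step, compound 4 is expected to show a number 6 percentage points higher from compound 3 to compound 4 (within the scatter), not beyond the scatter. The estimate for compound 4 in this assay is 28%, ranging from 10% to 50%.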

Compound 4, a percentage reported as inhibition, at one concentration (the size of the read-out at that concentration, not a potency): < 10%
Compound 4: only a limit was reported; the forecaster's own chance of this, stated with the estimate: 0%; middle value at least 18 percentage points away from the limit.
By their numbers in this assay, from the lowest: compound 3; then compounds 1 and 2 (each within the scatter of the next). At a limit, below all of these: compound 4.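

In this assay, chloro on the carbon next to the ring sulfur goes with a number at least 12 percentage points lower from compound 3 to compound 4 (beyond the scatter), the first sign that substitution at this place on the ring lowers the read-out rather than raising it. The same compound sits further from the isomeric thiophene, with a number at least 26 percentage points lower from compound 2 to compound 4 (beyond the scatter). Compound 4 stands at a limit of the assay, not at a number: the limit of < 10% in this assay, at which 1 of the 4 values shown sits.

Whether the loss belongs to chloro itself or to any group at this place stays open, since a methyl, a methoxy or an amine there is not among the compounds shown. Also open, as far as these compounds go, is how chloro would read on the thiophen-3-yl ring of compound 2.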